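This account rests on a few compounds, and the source may have more. Where it says the series, first, only, none or still open, it means among the compounds named here.

Measured so far in an ADME assay on microsomes from liver (Mus musculus) for metabolic stability, read by LC-MS, using NADPH, with stated times of 5 min and 30 min, at 37 degrees C; a lower number here means that the compound disappears faster, a higher number that the compound lasts longer:
compound 1 `COC(=O)c1cccc(CC[C@H]([C@H](C)O)n2cnc3c(N)ncnc32)c1`: > 0.5 h
compound 2 `C[C@H](O)[C@@H](CCc1cccc(-c2nccs2)c1)n1cnc2c(N)ncnc21`: > 0.5 h
compound 3 `C[C@H](O)[C@@H](CCc1cccc(-c2cnccn2)c1)n1cnc2c(N)ncnc21`: > 0.5 h

Compound 3 stands at a limit of this assay, not at a number, and the two other measured compounds stand at the same limit. The steps a step that the two limits leave unreadable from compound 1 to compound 2, a step that the two limits leave unreadable from compound 1 to compound 3 and a step that the two limits leave unreadable from compound 2 to compound 3 are therefore unreadable because of the limit of > 0.5 h in this assay, at which 3 of the 3 values shown sit.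

Compound 4 `CNC(=O)c1cccc(CC[C@H]([C@H](C)O)n2cnc3c(N)ncnc32)c1` differs from compound 3 by methylcarbamoyl in place of pyrazin-2-yl on an aromatic carbon. Within the data shown here, no measured step covers this change, and the three unreadable steps give neither a size nor a direction for it. Compound 4 is expected to sit at the limit again, so the step that the limit leaves unreadable from compound 3 to compound 4 is an estimate without a readable basis. For compound 4 the expected value is 0.8 h, ranging from 0.4 h to 2 h.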

Compound 4, half-life: > 0.5 h
Compound 4: a limit, no number (the forecaster's own chance of this, stated with the estimate: 75%); the middle value lies beyond the limit too.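

Compound 4 gives no readable step against compound 1, compound 2 or compound 3, because all four stand at the same limit: the limit of > 0.5 h in this assay, at which 4 of the 4 values shown sit. Going by these compounds, the actual half-life of each compound stays open, as does whether methoxycarbonyl, 1,3-thiazol-2-yl, pyrazin-2-yl and methylcarbamoyl differ at all.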